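A few compounds are considered here, and "the series" means these few. Any claim that something is new, unique, unknown or untested is made for them only; others in the source may bear on it.

In a toxicity assay on GES1 cells (Homo sapiens) for inhibition, read by MTT assay, with a stated time of 72 h (a higher number here means a weaker inhibitor, a lower number a stronger inhibitor), compound 1 `Cc1cc(N2CC[C@@H](C)[C@@H](N(C)c3ncnc4[nH]ccc34)C2)n2ncnc2n1` gives 57900 nM, and compound 2 `Cc1cc(N2CC[C@@H](C)[C@@H](N(C)c3ncnc4[nH]ccc34)C2)n2nc(SCc3nc4ccccc4[nH]3)nc2n1` gives 40200 nM. Compound 3 `Cc1cc(N2CC[C@@H](C)[C@@H](N(C)c3ncnc4[nH]ccc34)C2)n2nc(SCc3ccccc3Br)nc2n1` gives > 100000 nM, which is a limit of the assay and not a number. Compound 4 `Cc1cc(N2CC[C@@H](C)[C@@H](N(C)c3ncnc4[nH]ccc34)C2)n2nc(SCCc3ccccc3)nc2n1`, not yet measured, has benzyl in place of 2-bromophenyl on a saturated chain carbon bound to a sulfur. Among the compounds with values here, no measured step makes this exact change. The nearest evidence is the swap on that same chain carbon, an at least 2.4-fold higher number from compound 2 to compound 3 (0.39 log units; beyond the scatter), with the side-chain additions a 1.4-fold lower number from compound 1 to compound 2 (0.16 log units; within the scatter) and an at least 1.7-fold higher number from compound 1 to compound 3 (0.23 log units; that floor lies within the scatter) as further context. These steps are all small or modest, so the expected change, an at least 1.2-fold lower number from compound 3 to compound 4 (0.09 log units; that floor lies within the scatter), is likewise modest and probably toward a lower number. For compound 4 the estimated value is 80000 nM, with an expected range from 35000 nM to 150000 nM.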

Compound 4, half-maximal inhibitory concentration: 66200 nM
For compound 4 the middle estimate is 1.2-fold (0.08 log units) above the measured one; low and high end bracket the measured number.
By their numbers in this assay, from the lowest: compounds 2, 1 and 4 (each within the scatter of the next). At a limit, above all of these: compound 3.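

Replacing hydrogen on the aromatic carbon with phenethylsulfanyl barely registers in this assay, a 1.1-fold higher number from compound 1 to compound 4 (0.06 log units; within the scatter), so this position accepts a chain without bromine and stays in the same range. Exchanging the 1H-benzimidazol-2-yl end for benzyl also stays small, a 1.6-fold higher number from compound 2 to compound 4 (0.22 log units; within the scatter). Removing the bromine and lengthening the chain together gives an at least 1.5-fold lower number from compound 3 to compound 4 (0.17 log units; that floor lies within the scatter), and that step starts from a limit of the assay, not a number: the limit of > 100000 nM in this assay, at which 1 of the 4 values shown sits.

A 2-bromophenethyl group would separate the effect of the bromine from that of the chain. As far as these compounds go, whether an amine or a carboxylic acid on this chain would move the number beyond the scatter remains open.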